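The source may report more compounds than this note shows. Statements on the series, on what has been measured and on what is new or still open speak of the compounds shown alone.

Measured so far in a functional assay on A549 cells (Homo sapiens) for antiproliferative activity, read by MTT assay, with a stated time of 48 h (a lower number here means a stronger inhibitor, a higher number a weaker inhibitor), for two compounds on the shared core:

Compound 1 `C=C(c1ccc2c(c1)C=CC(C)(C)O2)c1ccc(OC)cc1NC(=O)CO` gives 40 nM here
Compound 2 `C=C(c1ccc2c(c1)C=CC(C)(C)O2)c1ccc(OC)cc1NC(=O)CNC` gives 200 nM here

Compound 2 has the higher of the two numbers, which makes it the weaker inhibitor, and compound 1 is its nearest neighbour. The next compound, compound 3 `C=C(c1ccc2c(c1)C=CC(C)(C)O2)c1ccc(OC)cc1NC(=O)CN(C)C`, differs from compound 2 in one place, with the change counted as methyl in place of hydrogen on an amine nitrogen in this comparison. This is methyl in place of hydrogen on an amine nitrogen, turning methylamino into dimethylamino.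

Among the compounds with values here, only one measured step bears on this change, and only indirectly. Replacing hydroxy with methylamino gave a 5.0-fold higher number from compound 1 to compound 2 (0.70 log units; beyond the scatter) in the same part of the molecule. That step lies beyond the scatter, so this end of the molecule can shift the number. However, it swapped a different group, and no measured pair shows what adding a methyl to an amine nitrogen does. A small rise in this assay or no change beyond the scatter is therefore expected. For compound 3 the expected value is 250 nM with an estimated range from 80 nM to 800 nM as the likely span. The estimated change is a 1.3-fold higher number from compound 2 to compound 3 (0.10 log units; within the scatter) on this reasoning.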

Compound 3, half-maximal inhibitory concentration: 430 nM
Compound 3: the middle estimate sits 1.7-fold (0.24 log units) below what was measured, and the stated range covers the measured number.
By their numbers in this assay, from the lowest: compound 1; then compound 2; then compound 3.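

In this assay, putting methyl in place of hydrogen on the amine nitrogen gives a 2.2-fold higher number from compound 2 to compound 3 (0.33 log units; beyond the scatter). Within the data shown here, this is the first measured sign that the amine nitrogen itself responds to a small addition, since the earlier step swapped one whole group for another. Comparing the two ends of the series, dimethylamino in place of hydroxy gives an 11-fold higher number from compound 1 to compound 3 (1.03 log units; beyond the scatter), a large step, so among these three compounds the number climbs from hydroxy to methylamino to dimethylamino, with none going against that order, though nothing measured here gives a reason for the climb.

The compounds shown leave open where a plain amino group, a methoxy group or a ring amine such as morpholine would fall in this order, and so whether hydroxy stands apart or the numbers simply rise with each carbon added to the nitrogen. From the compounds shown here alone, a longer chain between the carbonyl and the hydroxy or the amine is equally open, as is whether the same order holds in any other cell line.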